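The source may report more compounds than this note shows. Statements on the series, on what has been measured and on what is new or still open speak of the compounds shown alone.

In a functional assay on SK-N-SH cells (Homo sapiens) for cytotoxicity, read by MTT assay, with a stated time of 48 h (a lower number here means a stronger inhibitor, a higher number a weaker inhibitor), compound 1 `COc1ccc(/C=C/c2cc(OC)c(OC)c(OC)c2-c2ccc(OC)cc2)cc1` gives 36000 nM and compound 2 `C=C(c1ccc(OC)cc1)c1cc(OC)c(OC)c(OC)c1-c1ccc(OC)cc1` gives 75000 nM, the higher of the two numbers. Compound 3 `C=C(c1ccc(OC)cc1)c1cc(OC)c(OC)c(OC)c1-c1ccccc1` departs from compound 2 by hydrogen in place of methoxy on an aromatic carbon: hydrogen in place of methoxy, para to a large group, turning 4-methoxyphenyl into phenyl. Within the data shown here, the only measured step, a 2.1-fold higher number from compound 1 to compound 2 (0.32 log units; beyond the scatter), is a change from 2-(4-methoxyphenyl)ethenyl to 1-(4-methoxyphenyl)ethenyl elsewhere on the molecule, so it bears only loosely on this change and gives no direction. No step beyond the scatter is therefore expected in this assay. The expected change is a 1.2-fold lower number from compound 2 to compound 3 (0.06 log units; within the scatter). Compound 3 is estimated at 65000 nM, with an expected range of 28000 nM to 150000 nM.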

Compound 3, half-maximal inhibitory concentration: 31000 nM
Compound 3: the middle estimate sits 2.1-fold (0.32 log units) above what was measured; the range from low to high includes it.
By their numbers in this assay, from the lowest: compounds 3 and 1 (each within the scatter of the next); then compound 2.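

Hydrogen in place of methoxy, para to a large group, gives a 2.4-fold lower number from compound 2 to compound 3 (0.38 log units; beyond the scatter) in this assay, so 4-methoxyphenyl to phenyl at this position moves the number beyond the scatter, towards stronger inhibition. Among these compounds, the earlier step changed only the ethenyl attachment, and this is the first reading on this aromatic position. No measured evidence bears on the origin of this step.

Open, on these data alone, is whether a hydroxyl, fluorine or an amine at this position would move the number in the same direction as hydrogen. Also open, as far as these compounds go, is whether the same change would hold on the 2-(4-methoxyphenyl)ethenyl series of compound 1.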